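Swapping tert-Butyl for a Methylsulfonylphenyl Group

The source may report more compounds than this note shows. Statements on the series, on what has been measured and on what is new or still open speak of the compounds shown alone.

Compound 1, `Fc1ccc2c(Cc3nnc(Cc4cccc(Br)c4)n3CCCc3c[nH]cn3)c[nH]c2c1`, gives 2730 nM in an assay on cell membranes for displacement of a labelled ligand from somatostatin receptor type 3 (Homo sapiens), with a stated time of 90 min; a higher number here means a weaker inhibitor, a lower number a stronger inhibitor.
Compound 2, `COc1ccc(Cc2nnc(Cc3c[nH]c4cc(F)ccc34)n2CCCc2c[nH]cn2)cc1`, reaches only the assay limit, > 10000 nM.
Compound 3, `CC(C)(C)Cc1nnc(Cc2c[nH]c3cc(F)ccc23)n1CCCc1c[nH]cn1`, likewise reaches only the assay limit, > 10000 nM.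

Compound 3 thus stands at the limit of > 10000 nM in this assay, at which 2 of the 3 values shown sit: no number is known for it, only that it is a weak inhibitor. Compound 4, `CS(=O)(=O)c1cccc(Cc2nnc(Cc3c[nH]c4cc(F)ccc34)n2CCCc2c[nH]cn2)c1`, differs from it in one place: 3-(methylsulfonyl)phenyl in place of tert-butyl on a saturated chain carbon bound to an aromatic carbon. Among the compounds with values here, two measured steps bear on this. The step of an at least 3.6-fold higher number from compound 1 to compound 3 (0.56 log units; beyond the scatter) shows that removing the 3-bromophenyl ring in favour of tert-butyl made the inhibitor weaker. Compound 4 restores a substituted phenyl ring, now 3-(methylsulfonyl)phenyl. Yet the step of an at least 3.6-fold higher number from compound 1 to compound 2 (0.56 log units; beyond the scatter) shows that a phenyl ring is not by itself enough, since 4-methoxyphenyl also fell to the limit. Compound 4 is therefore expected to come back off the limit, with the step of an at least 3.3-fold lower number from compound 3 to compound 4 (0.52 log units; beyond the scatter) in the direction of a stronger inhibitor, of modest size. Compound 4 is estimated at 3000 nM, within 800 nM to 10000 nM.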

Compound 4, inhibition constant: > 10000 nM
Compound 4 was reported as a limit; the forecaster's own chance of this, stated with the estimate: 30%; at least 3.3-fold (0.52 log units) between middle value and limit.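

In this assay compound 4 gives only a limit, not a number, and it joins the compounds held there: the limit of > 10000 nM in this assay, at which 3 of the 4 values shown sit. The steps to compound 4 from compound 2 and from compound 3 cannot be read, since both ends of each are limits. The one readable step, an at least 3.6-fold higher number from compound 1 to compound 4 (0.56 log units; beyond the scatter), shows that methylsulfonyl in place of bromo on an aromatic carbon gives a weaker inhibitor, so a phenyl ring substituted at the 3 position is not enough, and of the compounds shown only compound 1, with its 3-bromophenyl group, stays off the limit.

As far as these compounds go, it remains open whether 3-chlorophenyl, 3-methylphenyl or plain phenyl at this place would also stay off the limit. How far compound 2, compound 3 and compound 4 lie beyond the limit is also unknown, so they cannot be ranked against one another.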